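The compounds below may be only part of what the source reports. "The series", "measured", "known", "first", "only" and "open" are said of these compounds alone.

In a functional assay on DU-145 cells (Homo sapiens) for inhibition, read by trypan blue exclusion, with a stated time of 96 h (on this read-out lower numbers stand for stronger inhibition of growth and higher numbers for weaker inhibition of growth), compound 1 (`CN(C)c1ccc(/C=C(/SCc2ccc(F)cc2)C(=O)c2ccc(Br)cc2)cc1`) gives 50000 nM, compound 2 (`O=C(/C(=C\c1ccc(Br)cc1)SCc1ccc(F)cc1)c1ccc(Br)cc1`) gives 25000 nM and compound 3 (`Cc1ccsc1/C=C(/SCc1ccc(F)cc1)C(=O)c1ccc(Br)cc1`) gives 50000 nM. Compound 3 thus stands level with compound 1 and within the scatter of compound 2. Compound 4 (`Cc1cc(F)ccc1/C=C(/SCc1ccc(F)cc1)C(=O)c1ccc(Br)cc1`) carries 4-fluoro-2-methylphenyl in place of 3-methylthiophen-2-yl on a double-bonded chain carbon bound to a double-bonded chain carbon. Two measured exchanges at this same place bear on it, no change at the digits printed from compound 1 to compound 3 (within the scatter) and a 2.0-fold higher number from compound 2 to compound 3 (0.30 log units; within the scatter), and both stay within the scatter. No step beyond the scatter, in either direction, is therefore expected in this assay. The expected change is a 1.4-fold lower number from compound 3 to compound 4 (0.15 log units; within the scatter). For compound 4 the estimated value is 35000 nM, with an expected range of 12000 nM to 70000 nM.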

Compound 4, concentration for 50% growth inhibition: 10000 nM
Compound 4: middle estimate off by 3.5-fold (0.54 log units), on the high side; measured number outside the range, below it.
By their numbers in this assay, from the lowest: compound 4; then compounds 2, 1 and 3 (each within the scatter of the next).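

Among these compounds, at this place, on a double-bonded chain carbon bound to a double-bonded chain carbon, 4-fluoro-2-methylphenyl brings the first steps beyond the scatter in this assay: a 5.0-fold lower number from compound 3 to compound 4 (0.70 log units; beyond the scatter) and a 5.0-fold lower number from compound 1 to compound 4 (0.70 log units; beyond the scatter) and also a 2.5-fold lower number from compound 2 to compound 4 (0.40 log units; beyond the scatter). The earlier groups here could not be told apart, so the position does respond to what it carries, and compound 4 has the lowest number of the four. Nothing measured here accounts for this step. 

As far as these compounds go, whether 4-fluorophenyl or 2-methylphenyl alone would match 4-fluoro-2-methylphenyl remains open. So does what a carboxylic acid or a longer chain would give at this place.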